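Working notes on oral exposure: from compound 3 to compound 4

The source may report more compounds than this note shows. Statements on the series, on what has been measured and on what is new or still open speak of the compounds shown alone.

Three members of the series have numbers in an ADME assay on the whole organism (Macaca fascicularis) for pharmacokinetics, read by LC-MS, using cassette dosing, at a dose of 1 mg/kg by the oral route; on this read-out lower numbers stand for lower exposure and higher numbers for higher exposure at the dose given. Compound 1 `CCCCN(c1nc2c(NS(C)(=O)=O)cccc2o1)[C@H](C)c1ccc(-c2ccccc2-c2nnn[nH]2)cc1` gives 73.8 ng.h/mL, compound 2 `CCCCN(c1nc2c(C(=O)N(C)C)cccc2o1)[C@H](C)c1ccc(-c2ccccc2-c2nnn[nH]2)cc1` gives 104 ng.h/mL, and compound 3 `CCCCN(c1nc2c(C(=O)O)cccc2o1)[C@H](C)c1ccc(-c2ccccc2-c2nnn[nH]2)cc1` gives 429 ng.h/mL. Within this set compound 3 stands highest: its margin over compound 2 is a 4.1-fold higher number from compound 2 to compound 3 (0.62 log units; beyond the scatter), and over compound 1 it is a 5.8-fold higher number from compound 1 to compound 3 (0.76 log units; beyond the scatter). Between compound 1 and compound 2 the step is a 1.4-fold higher number from compound 1 to compound 2 (0.15 log units; within the scatter).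

Compound 4 `CCCCN(c1nc2c(-c3ccccn3)cccc2o1)[C@H](C)c1ccc(-c2ccccc2-c2nnn[nH]2)cc1` is not yet measured. It differs from compound 3 as follows: pyridin-2-yl in place of carboxy on an aromatic carbon.

For the measured compounds named here, two measured steps bear on this change, both ending at the carboxy compound: the step of a 5.8-fold higher number from compound 1 to compound 3 (0.76 log units; beyond the scatter) and the step of a 4.1-fold higher number from compound 2 to compound 3 (0.62 log units; beyond the scatter) show that the two neutral groups tried at this place gave lower exposure than carboxy. Pyridin-2-yl is likewise a group without a hydrogen-bond donor, so the expectation is that compound 4 loses part of the exposure of compound 3, with an estimated step of a 3.6-fold lower number from compound 3 to compound 4 (0.55 log units; beyond the scatter). Compound 4 is therefore expected to give about 120 ng.h/mL in this assay, in a range from 40 ng.h/mL to 350 ng.h/mL.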

Compound 4, area under the concentration-time curve: 248 ng.h/mL
For compound 4 the middle estimate is 2.1-fold (0.32 log units) below the measured one, within the range that was stated.
By their numbers in this assay, from the lowest: compounds 1 and 2 (each within the scatter of the next); then compounds 4 and 3 (each within the scatter of the next).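

In this assay, the change from carboxy to pyridin-2-yl on this aromatic carbon gives a 1.7-fold lower number from compound 3 to compound 4 (0.24 log units; within the scatter), so the two groups cannot be told apart on this read-out, although pyridin-2-yl has 0 hydrogen-bond donors and brings a six-membered aromatic ring to the place where carboxy stood. The margin that carboxy held over dimethylcarbamoyl and methanesulfonamido therefore does not extend to every replacement at this position: pyridin-2-yl also separates from those two groups, with a 2.4-fold higher number from compound 2 to compound 4 (0.38 log units; beyond the scatter) and a 3.4-fold higher number from compound 1 to compound 4 (0.53 log units; beyond the scatter). Nothing at hand gives a measured reason for these differences in exposure.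

The compounds shown leave open whether the ring nitrogen of pyridin-2-yl matters, which a plain phenyl group or a pyridin-3-yl group on the same aromatic carbon would help to settle. They also leave open whether a basic group such as an aminomethyl substituent, or a small five-membered aromatic ring such as oxazol-2-yl, would stay level with carboxy and pyridin-2-yl or fall back towards dimethylcarbamoyl and methanesulfonamido.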